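The source may report more compounds than this note shows. Statements on the series, on what has been measured and on what is new or still open speak of the compounds shown alone.

Measured compounds and their values:

Compound 1 `NC1=NC2(CCSCC2)N(OCCCOc2ccc(Cl)c(Cl)c2)C(N)=N1`: 1 nM
Compound 2 `NC1=NC2(CCOCC2)N(OCCCOc2ccc(F)cc2)C(N)=N1`: 3280 nM
Compound 3 `Cc1cc(C)cc(OCCCON2C(N)=NC(N)=NC23CCOCC3)c1`: 190 nM

In a functional assay on HCT-116 cells (Homo sapiens) for antiproliferative activity, read by MTT assay, with a stated time of 72 h (on this read-out lower numbers stand for stronger inhibition and higher numbers for weaker inhibition), compound 1 gives the lowest number of the three, with 1 nM; compound 3 comes nearest at 190 nM, and compound 2 lies furthest away at 3280 nM, both gaps well beyond the scatter. Among the compounds with values here, the only measured step is the one between compounds that share a different core: a 17-fold lower number from compound 2 to compound 3 (1.24 log units; beyond the scatter). Compound 4 `NC1=NC2(CCSCC2)N(OCCCOc2ccc(Cl)cc2)C(N)=N1` keeps the core of compound 1 and differs from it in one place: hydrogen in place of chloro on an aromatic carbon. Within the data shown here, no measured pair shows the removal of a single chloro group, so the step from compound 2 to compound 3 bears on it only loosely, as a sign that the aryl group on the chain can move the number a long way. Since compound 1 sits at the extreme low end of what has been seen, a change there has more room to raise the number than to lower it. Compound 4 is therefore expected to give a weaker result than compound 1, with an estimated 10-fold higher number from compound 1 to compound 4 (1.00 log units; beyond the scatter). The estimate for compound 4 is 10 nM, within a range from 2 nM to 100 nM.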

Compound 4, half-maximal inhibitory concentration: 10 nM
Compound 4: middle estimate and measured number agree at the digits printed, and the stated range covers the measured number.
By their numbers in this assay, from the lowest: compound 1; then compound 4; then compound 3; then compound 2.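

Within the data shown here, this is the first measured pair in which a single chloro group is the only difference: in this assay, going from 3,4-dichlorophenyl to 4-chlorophenyl gives a 10-fold higher number from compound 1 to compound 4 (1.00 log units; beyond the scatter). The result shows that this aromatic carbon, ortho to a chloro group and meta to a large group, is not a silent place, as the loss of one heavy atom moves the number beyond the usual scatter, while compound 4 still gives 10 nM without that chloro group. Nothing measured here explains why this change has this effect on the cells.

The compounds shown do not tell whether another group on this same carbon, such as a methoxy group, a nitrile or an amine, would give a number closer to that of compound 1 or further from it. They also leave open what happens when the remaining chloro group is replaced by hydrogen to give an unsubstituted phenyl, and whether the same chloro change would have a step of similar size on the core of compound 2.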